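Phenyl substituent changes on the shared core

A few compounds are considered here, and "the series" means these few. Any claim that something is new, unique, unknown or untested is made for them only; others in the source may bear on it.

Among the compounds with values here, compound 1 `COc1cc(-c2ccnc3cc(-c4ccc(C)cc4)nn23)cc(OC)c1OC` holds the lowest of the three numbers so far: in a functional assay on MCF7 cells (Homo sapiens) for inhibition, read by CCK-8 assay, with a stated time of 48 h (a lower number here means a stronger inhibitor, a higher number a weaker inhibitor), compound 1 gives 47 nM. Compound 3 `COc1cc(-c2ccnc3cc(-c4c[nH]c5ccccc45)nn23)cc(OC)c1OC` stands nearest, giving 85 nM, and the step of a 1.8-fold higher number from compound 1 to compound 3 (0.26 log units; within the scatter). Compound 2 `COc1cc(-c2ccnc3cc(-c4ccc(C(C)=O)cc4)nn23)cc(OC)c1OC` lies furthest, giving 5230 nM, after the step of a 110-fold higher number from compound 1 to compound 2 (2.05 log units; beyond the scatter). Compound 4 `COc1cc(-c2ccnc3cc(-c4cccc(C#N)c4)nn23)cc(OC)c1OC` differs from compound 1 by 3-cyanophenyl in place of 4-methylphenyl on an aromatic carbon. Both measured steps bear on it, as each exchanges the aryl group: the acetyl step was large, the 1H-indol-3-yl step within the scatter. The nitrile, like the acetyl, is a substituent on the phenyl. Some loss is expected, though smaller than a 110-fold higher number from compound 1 to compound 2 (2.05 log units; beyond the scatter). Compound 4 is therefore expected to give about 150 nM, estimated between 40 nM and 800 nM. The expected step is a 3.2-fold higher number from compound 1 to compound 4 (0.50 log units; beyond the scatter).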

Compound 4, half-maximal inhibitory concentration: > 10000 nM
Compound 4: no number, only a limit (the forecaster's own chance of this, stated with the estimate: 3%); middle value at least 66-fold (1.82 log units) from the limit.
By their numbers in this assay, from the lowest: compounds 1 and 3 (each within the scatter of the next); then compound 2. At a limit, above all of these: compound 4.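

In this assay compound 4 carries a limit and not a number: the limit of > 10000 nM in this assay, at which 1 of the 4 values shown sits. A second phenyl substituent, after the acetyl of compound 2, now gives a large step at this aromatic carbon, with an at least 210-fold higher number from compound 1 to compound 4 (2.32 log units; beyond the scatter) and an at least 110-fold higher number from compound 3 to compound 4 (2.07 log units; beyond the scatter), so this place does not accept every aryl group. Against the acetyl, an at least 1.9-fold higher number from compound 2 to compound 4 (0.28 log units; that floor lies within the scatter), so compound 2 and compound 4 are not separated.

As far as these compounds go, whether the loss follows the nitrile itself or where it sits on the phenyl stays open. So does how 4-cyanophenyl, or an amine or a carboxylic acid on the phenyl, would read.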